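Carboxylic acid chain variants on a shared quinolinylmethoxyphenyl core

This account rests on a few compounds, and the source may have more. Where it says the series, first, only, none or still open, it means among the compounds named here.

Two compounds of the series have numbers in an assay on membranes from lung (Cavia porcellus) for binding affinity to cysteinyl leukotriene receptor (Homo sapiens); on this read-out lower numbers stand for stronger inhibition and higher numbers for weaker inhibition. Compound 1 `O=C(O)CCCOc1ccc(OCc2ccc3ccccc3n2)cc1` carries the acid on an ether-linked chain; in this assay compound 1 gives 1200 nM. Compound 2 `O=C(O)CC1(CCc2ccc(OCc3ccc4ccccc4n3)cc2)CCCC1` holds the acid on a carboxymethyl group fixed to a cyclopentyl ring; in this assay compound 2 gives 51 nM. Compound 2 therefore stands at the lower of the two numbers, with compound 1 well beyond the scatter above it.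

Compound 3 `O=C(O)CCCCc1ccc(OCc2ccc3ccccc3n2)cc1` is the next member to be measured. It differs from compound 2 in one place: 2-carboxyethyl in place of 1-(carboxymethyl)cyclopentyl on a saturated chain carbon, two bonds along the chain from an aromatic carbon. The ring is removed and the acid sits on an open chain of the count given, while the rest of the shared core is unchanged. Among the measured compounds shown here, no measured pair shows this particular step, so its size is not known from the data.

The expectation is that this assay reports a step of a 5.9-fold higher number from compound 2 to compound 3 (0.77 log units; beyond the scatter), that is a move toward a higher number. For compound 3 the estimated value is 300 nM, with a range from 100 nM to 1000 nM.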

Compound 3, inhibition constant: 110 nM
Compound 3: the middle estimate sits 2.7-fold (0.44 log units) above what was measured, within the range that was stated.
By their numbers in this assay, from the lowest: compound 2; then compound 3; then compound 1.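

In this assay, 2-carboxyethyl in place of 1-(carboxymethyl)cyclopentyl on a saturated chain carbon, two bonds along the chain from an aromatic carbon, gives a 2.2-fold higher number from compound 2 to compound 3 (0.33 log units; beyond the scatter); this step is modest but beyond the scatter, so the ring is not needed for a number in this range, though the ringed compound 2 keeps the lower number. Among the compounds shown here, compound 3 also gives the first one-place reading at the link to the aromatic carbon: 4-carboxybutyl in place of 3-carboxypropoxy on an aromatic carbon gives an 11-fold lower number from compound 1 to compound 3 (1.04 log units; beyond the scatter), a large step that outweighs the modest one from the loss of the ring. Nothing available explains either step.

The compounds shown leave open how a longer chain ending in the carboxylic acid would read, and whether the ring in compound 2 would give the same step on a chain joined through an ether oxygen. They also leave open whether the carboxylic acid itself can give way to an amide on the same shared core.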